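The source may report more compounds than this note shows. Statements on the series, on what has been measured and on what is new or still open speak of the compounds shown alone.

Measured in a functional assay on XF498 cells (Homo sapiens) for cytotoxicity, read by MTT assay, with a stated time of 72 h; on this read-out higher numbers stand for weaker inhibition and lower numbers for stronger inhibition:
compound 1 `CCOc1ccc(NC2=CC(=O)c3ncncc3C2=O)cc1` gives 0.03 ug/mL
compound 2 `O=C1C(Nc2ccccc2)=CC(=O)c2ncncc21` gives 0.01 ug/mL
compound 3 `O=C1C(Nc2ccc(I)cc2)=CC(=O)c2ncncc21` gives 0.04 ug/mL

Compound 3 cannot be told apart from compound 1, as a 1.3-fold higher number from compound 1 to compound 3 (0.12 log units; within the scatter) shows. It is clearly weaker than compound 2, as a 4.0-fold higher number from compound 2 to compound 3 (0.60 log units; beyond the scatter) shows. Compound 4 `O=C1C(Nc2ccc(Cl)cc2)=CC(=O)c2ncncc21` keeps the shared core and carries chloro in place of iodo on an aromatic carbon. For the measured compounds named here, no measured step makes this exchange directly. The closest evidence is the modest step of a 4.0-fold higher number from compound 2 to compound 3 (0.60 log units; beyond the scatter), so a small move back towards compound 2 seems likely in this assay, probably not beyond the scatter. The expected change is a 1.6-fold lower number from compound 3 to compound 4 (0.20 log units; within the scatter). For compound 4 the estimated value is 0.025 ug/mL, with an expected range from 0.01 ug/mL to 0.06 ug/mL.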

Compound 4, half-maximal inhibitory concentration: 0.01 ug/mL
Beside the measured number, compound 4's estimate is 2.5-fold (0.40 log units) above it; the range from low to high includes it.
By their numbers in this assay, from the lowest: compounds 2 and 4 (each within the scatter of the next); then compounds 1 and 3 (each within the scatter of the next).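

In this assay the exchange of iodo for chloro on this aromatic carbon gives a 4.0-fold lower number from compound 3 to compound 4 (0.60 log units; beyond the scatter) and so shows that the two halogens are not interchangeable at this position. Chloro also parts from ethoxy, with a 3.0-fold lower number from compound 1 to compound 4 (0.48 log units; beyond the scatter) on that exchange, while no change at the digits printed from compound 2 to compound 4 (within the scatter) puts chloro level with hydrogen, a level that neither iodo nor ethoxy reached. Nothing shown explains why chloro and iodo differ here.

The compounds shown leave open where bromo or fluoro would fall relative to chloro and iodo. They also leave open how an amine or a carboxylic acid would fare at this place.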